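Dropping the chloro from the benzyl arm of compound 2

This account rests on a few compounds, and the source may have more. Where it says the series, first, only, none or still open, it means among the compounds named here.

The two measured compounds share one core and differ only in the benzyl arm. Compound 1 `Cc1cc(S(=O)(=O)/N=C(\N)n2nccc2-c2ccccc2)c(SCc2ccccc2Cl)cc1Cl` gives 20000 nM in an ADME assay on HaCaT cells (Homo sapiens) for cytotoxicity, read by MTT assay, with a stated time of 72 h (a higher number here means a weaker inhibitor, a lower number a stronger inhibitor), and compound 2 `Cc1cc(S(=O)(=O)/N=C(\N)n2nccc2-c2ccccc2)c(SCc2cccc(Cl)c2)cc1Cl` gives 10000 nM. Among the compounds with values here, the one step between them, a 2.0-fold lower number from compound 1 to compound 2 (0.30 log units; within the scatter), is small, so compound 2 stands on the lower of two numbers that cannot be told apart. Compound 3 `Cc1cc(S(=O)(=O)/N=C(\N)n2nccc2-c2ccccc2)c(SCc2ccccc2)cc1Cl` differs from compound 2 by hydrogen in place of chloro on an aromatic carbon. Within the data shown here, no measured step removes a chloro from this ring; the single step that bears on the question, a 2.0-fold lower number from compound 1 to compound 2 (0.30 log units; within the scatter), only moved the chloro and stayed within the scatter. On that basis compound 3 is expected to sit close to compound 2, with a step of a 1.5-fold higher number from compound 2 to compound 3 (0.18 log units; within the scatter) that is expected to stay within the scatter. The estimate for compound 3 is 15000 nM, with a range from 6000 nM to 40000 nM.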

Compound 3, half-maximal inhibitory concentration: 18000 nM
Compound 3: the middle estimate sits 1.2-fold (0.08 log units) below what was measured; the measured number falls inside the stated range.
By their numbers in this assay, from the lowest: compounds 2, 3 and 1 (each within the scatter of the next).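

In this assay taking the chloro off altogether gives a 1.8-fold higher number from compound 2 to compound 3 (0.26 log units; within the scatter) and, counted from the other chlorinated arm, a 1.1-fold lower number from compound 1 to compound 3 (0.05 log units; within the scatter). The earlier step had only moved the chloro around this six-membered aromatic ring, whereas these two steps compare its presence with its absence, and in neither case can the change be told apart from the scatter. So across the three compounds, the 2-chlorophenyl arm, the 3-chlorophenyl arm and the plain phenyl arm cannot be separated in this read-out, and no supporting evidence accounts for that result.

On these data alone, what remains open is whether a different group on this ring, such as an amine or a carboxylic acid, would take the number beyond the scatter. A longer chain between the sulfur and the ring is equally unresolved.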